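The compounds below may be only part of what the source reports. "The series", "measured", "known", "first", "only" and "open" are said of these compounds alone.

Measured compounds:
compound 1 `COc1ccc(/C=C(\C#N)C(=O)c2cc(OC)c(OC)c(OC)c2)cc1O`, 4200 nM
compound 2 `COc1cc(C(=O)/C(C#N)=C/c2ccc(OC)c(OC)c2OC)cc(OC)c1OC`, > 10000 nM

Going by the values given here, in an ADME assay on K562 cells (Homo sapiens) for cytotoxicity, read by MTT assay, with a stated time of 5 days (on this read-out lower numbers stand for stronger inhibition and higher numbers for weaker inhibition), compound 1 gives 4200 nM, the only numerical value in this small set. For compound 2 the read-out in this assay is a limit of the assay, > 10000 nM, not a number. Among the compounds with values here, no step between compound 1 and compound 2 can therefore be sized; what the two values show is summarised by the limit of > 10000 nM in this assay, at which 1 of the 2 values shown sits.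

Compound 3 `COc1ccc(/C=C(\C#N)C(=O)c2cc(OC)c(OC)c(OC)c2)cc1F` has not been measured in this assay. It differs from compound 1 in one place: fluoro in place of hydroxy on an aromatic carbon, ortho to a methoxy group, so that a 3-hydroxy-4-methoxyphenyl becomes a 3-fluoro-4-methoxyphenyl. Within the data shown here, no measured step covers this exchange, so the expectation rests on compound 1 alone. The step of a 1.3-fold higher number from compound 1 to compound 3 (0.12 log units; within the scatter) is expected to be small, within or only just beyond the scatter, with weaker inhibition somewhat more likely than stronger. Compound 3 is accordingly estimated at 5500 nM in this assay, within a range of 1500 nM to 15000 nM, with a fair chance that only a limit is reported.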

Compound 3, half-maximal inhibitory concentration: > 10000 nM
Compound 3 gave a limit, no number; the forecaster's own chance of this, stated with the estimate: 25%; middle value at least 1.8-fold (0.25 log units) from the limit.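

In this assay compound 3 gives > 10000 nM, which is a limit of the assay and not a number. This gives the series its first sized step at this position, on the aromatic carbon ortho to a methoxy group: fluoro in place of hydroxy produces an at least 2.3-fold higher number from compound 1 to compound 3 (0.37 log units; beyond the scatter), so the change is not neutral here, and the 3-hydroxy-4-methoxyphenyl of compound 1 reads better in this assay than the 3-fluoro-4-methoxyphenyl of compound 3. With this result, compound 1 remains the only compound shown with a numerical value, and the other read-outs give no measure of how far the loss extends: the limit of > 10000 nM in this assay, at which 2 of the 3 values shown sit.

The hydroxy counts as a hydrogen-bond donor and acceptor and the fluoro as neither, but a single exchange cannot show whether the step follows from losing the hydroxy or from introducing the fluoro, and the true size of the step stays hidden behind the limit. As far as these compounds go, how an amino group or a chloro at this position would read against compound 1 also remains open.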